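Formyl in place of methyl on the aryl arm

The compounds below may be only part of what the source reports. "The series", "measured", "known", "first", "only" and "open" are said of these compounds alone.

Measured so far:
compound 1 `O=Cc1ccc(-c2cn3ccnc3c(-c3ccc4ncn(C5CCCCC5)c4c3)n2)cc1` gives 54.5%
compound 2 `CCc1ccc(-c2cn3ccnc3c(-c3ccc4ncn(Cc5ccccc5)c4c3)n2)cc1` gives 23%
compound 3 `Cc1cccc(-c2cn3ccnc3c(-c3ccc4ncn(Cc5ccccc5)c4c3)n2)c1` gives 9.09%

All three share one core and were tested in a functional assay on NCI-H23 cells (Homo sapiens) for inhibition, read by sulforhodamine B assay, with a stated time of 48 h, tested at 10 uM; a lower number here means less inhibition, a higher number more inhibition at the concentration tested (going by the name of the read-out). Compound 3 stands lowest of the three; its nearest neighbour, compound 2, lies higher by a margin beyond the scatter, and compound 1 lies far above it. Among the measured compounds shown here, the only step between compounds that differ in one place is a number 13.9 percentage points lower from compound 2 to compound 3 (beyond the scatter), a modest drop.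

Compound 4 `O=Cc1ccc(-c2cn3ccnc3c(-c3ccc4ncn(Cc5ccccc5)c4c3)n2)cc1` is the next compound to be measured in this assay. It differs from compound 3 by 4-formylphenyl in place of 3-methylphenyl on an aromatic carbon. For the measured compounds named here, no measured step covers a formyl group replacing a methyl group directly. Compound 4 shares its 4-formylphenyl with compound 1 but differs from it in another part of the molecule. The value of compound 1, 54.5%, can therefore only hint, not predict. Going by the values given here, the one step known, from a 4-ethylphenyl to a 3-methylphenyl, shows that swapping this aryl arm moves the number by a modest amount.

Taken together, a rise beyond the scatter is expected for compound 4, a number 23.9 percentage points higher from compound 3 to compound 4 (beyond the scatter), with much uncertainty. Compound 4 is estimated at 33%, likely between 8% and 60%.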

Compound 4, a percentage reported as inhibition, at one concentration (the size of the read-out at that concentration, not a potency): 54.5%
Compound 4: middle estimate off by 21.5 percentage points, on the low side; low and high end bracket the measured number.
By their numbers in this assay, from the lowest: compound 3; then compound 2; then compounds 1 and 4 (each within the scatter of the next).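

In this assay, 4-formylphenyl in place of 3-methylphenyl on this aromatic carbon gives a number 45.4 percentage points higher from compound 3 to compound 4 (beyond the scatter), a change of both the group and its place on the phenyl ring. Formyl in place of ethyl, which keeps the place on that ring, gives a number 31.5 percentage points higher from compound 2 to compound 4 (beyond the scatter), so the result does not rest on the shift of place alone, and this position can move the number far more than the first step between compound 2 and compound 3 suggested. With the 4-formylphenyl held constant, benzyl in place of cyclohexyl on the aromatic nitrogen gives no change at the digits printed from compound 1 to compound 4 (within the scatter), so for this pair that exchange leaves the read-out within the scatter, and no measurement at hand explains any of these results.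

The compounds shown leave open whether formyl is special at this position, or whether an amine, a carboxylic acid or a nitrile in its place would give a similar number. They also leave open whether benzyl and cyclohexyl would still match if the aryl arm carried 4-ethylphenyl instead of 4-formylphenyl.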